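The source may report more compounds than this note shows. Statements on the series, on what has been measured and on what is new or still open speak of the compounds shown alone.

Compound 1 `CCC(CO)NCc1nc2c(OCC3CCCCC3)cccc2[nH]1` stands at the top of the two measurements made so far. In an assay on cells for inhibition of interleukin-5 receptor subunit alpha (Mus musculus), read by WST assay, with a stated time of 48 h, tested at 30 uM, in the presence of a further agent that is not named here (on this read-out lower numbers stand for less inhibition and higher numbers for more inhibition at the one concentration tested (going by the name of the read-out)), compound 1 gives 94.3%. Compound 2 `OCCC(NCc1nc2c(OCC3CCCCC3)cccc2[nH]1)c1ccccc1`, which carries a different group on the same amine nitrogen, gives 64.7% in this assay, a reading that lies well beyond the usual scatter below that of compound 1. Among the measured compounds shown here, the only comparison available therefore shows that changing the group on the amine nitrogen can cost a substantial part of the inhibition.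

Compound 3 `COc1ccc(NCc2nc3c(OCC4CCCCC4)cccc3[nH]2)cc1` has not yet been measured. It differs from compound 1 in one place: 4-methoxyphenyl in place of 1-(hydroxymethyl)propyl on an amine nitrogen. No such replacement has been measured in this series, so the expectation rests on compound 2, whose value 64.7% suggests a drop when the amine substituent is altered. Compound 3 is therefore expected to fall below compound 1 in this assay, by an estimated step of a number 39.3 percentage points lower from compound 1 to compound 3 (beyond the scatter). The reading of compound 3 is estimated at 55%, with a likely range from 25% to 85%.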

Compound 3, a percentage reported as inhibition, at one concentration (the size of the read-out at that concentration, not a potency): 20.3%
Compound 3: the middle estimate sits 34.7 percentage points above what was measured; the measured number lies below the stated range.
By their numbers in this assay, from the lowest: compound 3; then compound 2; then compound 1.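

In this assay, putting 4-methoxyphenyl in place of 1-(hydroxymethyl)propyl on the amine nitrogen gives a number 74 percentage points lower from compound 1 to compound 3 (beyond the scatter). This shows that a change at this nitrogen can remove most of the inhibition seen with compound 1, not just part of it. The change alters several things at once, replacing an open chain with a six-membered aromatic ring, adding heavy atoms and removing the hydrogen-bond donor, and no available data indicate which of these accounts for the loss.

On these data alone, it remains open whether the hydroxyl group of compound 1 matters, which a plain propyl group on the same nitrogen would help to test. A 4-hydroxyphenyl group would similarly show whether restoring a hydroxyl group on the ring recovers any inhibition.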